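The compounds below may be only part of what the source reports. "The series", "measured", "known", "first", "only" and "open" are said of these compounds alone.

Compound 2 `C/C1=C\CC(C)(C)/C=C/C(=O)N(Cc2cn(CCOc3ccc(C(=O)/C=C/c4ccc(C)cc4)c(O)c3)nn2)/C(C)=C/CC1` has been tested in a functional assay on P338 cells (Mus musculus) for antiproliferative activity (on this read-out higher numbers stand for weaker inhibition and lower numbers for stronger inhibition), where compound 2 gives 0.92 ug/mL. For the measured compounds named here, the only other compound measured so far is compound 1 `COc1ccccc1/C=C/C(=O)c1ccc(OCCn2cc(CN3C(=O)/C=C/C(C)(C)C/C=C(\C)CC/C=C/3C)nn2)cc1O`, and in this assay compound 1 gives 1.1 ug/mL. The two numbers sit close together: the step of a 1.2-fold lower number from compound 1 to compound 2 (0.08 log units; within the scatter) shows that exchanging one aryl group for another left the read-out essentially unchanged. Compound 2 therefore stands at one of two very similar numbers, with no separation from compound 1.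

Compound 3 `C/C1=C\CC(C)(C)/C=C/C(=O)N(Cc2cn(CCOc3ccc(C(=O)/C=C/c4ccc(C(C)C)cc4)c(O)c3)nn2)/C(C)=C/CC1` has not yet been tested. It differs from compound 2 by one change: isopropyl in place of methyl on an aromatic carbon. Going by the values given here, the one measured step that bears on this, a 1.2-fold lower number from compound 1 to compound 2 (0.08 log units; within the scatter), also altered the group on this part of the molecule, and it stayed within the scatter. A small move, if any, is expected because a 1.2-fold lower number from compound 1 to compound 2 (0.08 log units; within the scatter) gave no shift beyond the scatter.

For compound 3 the expected result in this assay is 0.9 ug/mL, with a likely range from 0.4 ug/mL to 2 ug/mL. This estimate means a step of a 1.0-fold lower number from compound 2 to compound 3 (0.01 log units; within the scatter) that is expected to remain within the scatter.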

Compound 3, half-maximal inhibitory concentration: 1.39 ug/mL
Compound 3: middle estimate off by 1.5-fold (0.19 log units), on the low side; measured number inside the range.
By their numbers in this assay, from the lowest: compounds 2, 1 and 3 (each within the scatter of the next).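

In this assay, the earlier pair only swapped one substituted phenyl group for another, whereas this result tests the size of the group on a single aromatic carbon, para to a large group: isopropyl, with 3 heavy atoms, replaces methyl, with 1 heavy atom, and the result is a 1.5-fold higher number from compound 2 to compound 3 (0.18 log units; within the scatter). Setting 4-isopropylphenyl in place of 2-methoxyphenyl gives a 1.3-fold higher number from compound 1 to compound 3 (0.10 log units; within the scatter), so all three steps among these aryl groups now lie within the scatter, and the two additional carbons of the isopropyl group produce no separable shift at this position. Nothing available here offers a reason for these small steps.

What the shown compounds leave open is whether this aromatic carbon would tolerate something other than a small group of carbon and hydrogen, such as an amine, a carboxylic acid or a longer chain. Also unresolved is whether a group of that kind would move the read-out beyond the scatter, which none of the steps among these three compounds has done.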